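Methylation of the indole nitrogen across a chain-extended pair

The compounds below may be only part of what the source reports. "The series", "measured", "known", "first", "only" and "open" are said of these compounds alone.

Compound 1 `CCCCCCCCCCCCNC(=O)[C@@H](NC(=O)c1cc2ccccc2[nH]1)[C@@H](C)O` and compound 3 `CCCCCCCCCCCCCCNC(=O)[C@@H](NC(=O)c1cc2ccccc2[nH]1)[C@@H](C)O` share a core in which only the chain end differs: ethyl in place of hydrogen on a saturated chain carbon, ten or more bonds along the chain from an amide-type nitrogen. In a functional assay on A-431 cells (Homo sapiens) for cytotoxicity, read by MTT assay, with a stated time of 48 h (a higher number here means a weaker inhibitor, a lower number a stronger inhibitor), compound 1 gives 10300 nM, and compound 3 gives 12300 nM, so that a 1.2-fold higher number from compound 1 to compound 3 (0.08 log units; within the scatter). Compound 2 `CCCCCCCCCCCCNC(=O)[C@@H](NC(=O)c1cc2ccccc2n1C)[C@@H](C)O` carries the change (methyl in place of hydrogen on an aromatic nitrogen), and in this assay compound 2 gives 169000 nM, which means a 16-fold higher number from compound 1 to compound 2 (1.22 log units; beyond the scatter). Compound 4 `CCCCCCCCCCCCCCNC(=O)[C@@H](NC(=O)c1cc2ccccc2n1C)[C@@H](C)O`, not yet measured, carries the same change on the core of compound 3: methyl in place of hydrogen on an aromatic nitrogen. The core difference between compound 1 and compound 3 is shown to leave the number almost unchanged. The same methylation is already seen as a 16-fold higher number from compound 1 to compound 2 (1.22 log units; beyond the scatter). A step of similar size is therefore expected: a 15-fold higher number from compound 3 to compound 4 (1.19 log units; beyond the scatter). Compound 4 is therefore estimated at 190000 nM, with a plausible range from 60000 nM to 600000 nM.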

Compound 4, half-maximal inhibitory concentration: 13700 nM
For compound 4 the middle estimate is 14-fold (1.14 log units) above the measured one; the measured number lies below the stated range.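

In this assay the methylation of the aromatic nitrogen does not carry from one core to the other, since it gives a 1.1-fold higher number from compound 3 to compound 4 (0.05 log units; within the scatter), and the two steps differ: the same change on two cores in this assay, a 16-fold higher number (1.22 log units; beyond the scatter) from compound 1 to compound 2 and a 1.1-fold higher number (0.05 log units; within the scatter) from compound 3 to compound 4, 15-fold (1.17 log units) apart, beyond the scatter of two such steps. The chain change, read on the methylated pair, gives a 12-fold lower number from compound 2 to compound 4 (1.09 log units; beyond the scatter), and it also differs from its step on the other pair: the same change on two cores in this assay, a 1.2-fold higher number (0.08 log units; within the scatter) from compound 1 to compound 3 and a 12-fold lower number (1.09 log units; beyond the scatter) from compound 2 to compound 4, 15-fold (1.17 log units) apart, beyond the scatter of two such steps. These four compounds show that in this assay each change depends on the core that carries it, but they do not show why, nor how either change would behave on any other core.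

Going by these compounds, it remains open whether a shorter or a longer chain, or an ethyl group on the aromatic nitrogen, would follow compound 2 or compound 4.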